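Formyl Removal on Allyl Biphenyl Ethers in HepG2 Cells

This account rests on a few compounds, and the source may have more. Where it says the series, first, only, none or still open, it means among the compounds named here.

Compound 1 `C=CCc1cc(C=O)c(OCC(=O)OCC)c(-c2ccc(OCC(=O)OCC)c(CC=C)c2)c1`: in a functional assay on HepG2 cells (Homo sapiens) for antiproliferative activity, read by MTT assay, with a stated time of 24 h (on this read-out higher numbers stand for weaker inhibition and lower numbers for stronger inhibition), compound 1 reaches only a limit of the assay, not a number, > 85200 nM.
Compound 2 `C=CCc1ccc(OCC(=O)OCC)c(-c2ccc(OCC(=O)OCC)c(CC=C)c2)c1`: in this assay compound 2 gives 68900 nM.
Compound 3 `C=CCc1cc(C=O)c(OCC)c(-c2ccc(OCC)c(CC=C)c2)c1`: in this assay compound 3 gives 28500 nM.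

Compound 4 `C=CCc1ccc(OCC)c(-c2ccc(OCC)c(CC=C)c2)c1` has not yet been measured in this assay. It stands to compound 3 as compound 2 stands to compound 1: hydrogen in place of formyl on an aromatic carbon. The change from compound 1 to compound 2 is hydrogen in place of formyl on an aromatic carbon, and it produced an at least 1.2-fold lower number from compound 1 to compound 2 (0.09 log units; that floor lies within the scatter), a step that starts from a limit, (the limit of > 85200 nM in this assay, at which 1 of the 3 values shown sits). The surroundings differ: in compound 3 the formyl sits ortho to an ethoxy group, in compound 1 ortho to a (ethoxycarbonyl)methoxy group, so the two changes are the same kind of change rather than the same. How the core of compound 3 differs from the core of compound 1 is not broken down here. Of the two measured numbers, compound 3 holds the lower, compound 2 being the nearest.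

The expected step is a 1.4-fold lower number from compound 3 to compound 4 (0.15 log units; within the scatter), a modest one; its size rests on an at least 1.2-fold lower number from compound 1 to compound 2 (0.09 log units; that floor lies within the scatter). Compound 4 is expected to give about 20000 nM in this assay, most likely between 8000 nM and 60000 nM.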

Compound 4, half-maximal inhibitory concentration: > 124000 nM
Compound 4: only a limit was reported (the forecaster's own chance of this, stated with the estimate: 10%); middle value at least 6.2-fold (0.79 log units) from the limit.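

In this assay, hydrogen in place of formyl gave an at least 4.3-fold higher number from compound 3 to compound 4 (0.63 log units; beyond the scatter), so this change did not carry over unchanged from the core of compound 1 to the core of compound 3: the same change on two cores in this assay, an at least 1.2-fold lower number (0.09 log units; that floor lies within the scatter) from compound 1 to compound 2 and an at least 4.3-fold higher number (0.63 log units; beyond the scatter) from compound 3 to compound 4, at least 5.3-fold (0.73 log units) apart, beyond the scatter of two such steps
The step to compound 4 ends at a limit of the assay, not at a number: the limit of > 124000 nM in this assay, at which 1 of the 4 values shown sits.
The step from compound 1 likewise starts from a limit, so the two steps show that the outcome of this change depended on the core, but they give the true size of neither step and do not show which feature of the cores decides it: the limit of > 85200 nM in this assay, at which 1 of the 4 values shown sits.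

The compounds shown leave open what other groups would do in the place of the formyl on the core of compound 3, such as a hydroxymethyl group, a carboxylic acid or an amine. They also leave open how the formyl change would behave with a longer chain in place of the ethoxy groups, or with a free carboxylic acid in place of the ethyl esters of compound 1.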